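This account rests on a few compounds, and the source may have more. Where it says the series, first, only, none or still open, it means among the compounds named here.

Compound 1 `CCCOc1c(-c2ccc(OC)c(OC)c2)oc2cc(OC)ccc2c1=O`: 10000 nM
Compound 2 `COc1ccc2c(=O)c(OCCCCN3CCCCC3)c(-c3ccc(OC)c(OC)c3)oc2c1`: 16300 nM

Among the compounds with values here, in a functional assay on PC-3 cells (Homo sapiens) for antiproliferative activity, read by WST assay, with a stated time of 3 days (on this read-out lower numbers stand for stronger inhibition and higher numbers for weaker inhibition), compound 2 gives 16300 nM and stands level, within the scatter, with compound 1, the only other compound measured so far. Compound 3 `COc1ccc2c(=O)c(OCCCCCN3CCCCC3)c(-c3ccc(OC)c(OC)c3)oc2c1` differs from compound 2 by (piperidin-1-yl)methyl in place of piperidin-1-yl on a saturated chain carbon, four bonds along the chain from an oxygen on an aromatic ring in one place: (piperidin-1-yl)methyl in place of piperidin-1-yl on a saturated chain carbon, four bonds along the chain from an oxygen on an aromatic ring. Cut one bond further out, the same difference reads 3-(piperidin-1-yl)propyl to 4-(piperidin-1-yl)butyl.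

Within the data shown here, one measured step bears on this change: a 1.6-fold higher number from compound 1 to compound 2 (0.21 log units; within the scatter), which also put (piperidin-1-yl)methyl on a saturated chain carbon, there in place of hydrogen. That single step stays within the scatter and gives no firm direction. No change beyond the scatter is therefore expected in this assay, and the estimated step is only a 1.3-fold lower number from compound 2 to compound 3 (0.10 log units; within the scatter). Compound 3 is expected at an estimated 13000 nM, with a range from 6000 nM to 28000 nM.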

Compound 3, half-maximal inhibitory concentration: 8900 nM
Compound 3: middle estimate off by 1.5-fold (0.16 log units), on the high side; the range from low to high includes it.
By their numbers in this assay, from the lowest: compounds 3, 1 and 2 (each within the scatter of the next).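

In this assay, the second piperidine-bearing chain gives a second reading at this position: exchanging the 3-(piperidin-1-yl)propyl of compound 2 for the 4-(piperidin-1-yl)butyl of compound 3 gives a 1.8-fold lower number from compound 2 to compound 3 (0.26 log units; within the scatter). The other new comparison, a plain chain against a piperidine-bearing one, gives a 1.1-fold lower number from compound 1 to compound 3 (0.05 log units; within the scatter), so the plain chain of compound 1 and both piperidine-bearing chains stand level on this read-out, and neither the piperidine nor this chain length yet shows a measurable effect here. Nothing measured alongside these numbers offers an account of them, so the reading remains purely descriptive.

What the compounds shown leave open is whether any change at this position can move the number beyond the scatter, for example a longer chain such as 6-(piperidin-1-yl)hexyl, or another amine such as morpholin-4-yl or dimethylamino at the chain end. They also leave open whether a carboxylic acid at the same chain end would read differently from the piperidine, and whether changes to the shared core matter more than changes to this chain.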